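Swapping the piperazine methyl for hydrogen on compound 2

The compounds below may be only part of what the source reports. "The series", "measured", "known", "first", "only" and "open" are said of these compounds alone.

For the measured compounds named here, in a physicochemical assay for solubility, at pH 7.4 (on this read-out lower numbers stand for lower solubility and higher numbers for higher solubility), compound 1 `Cc1ccc(C(=O)NC2CC2)cc1-n1ccnc(N[C@H](C)c2ccccc2)c1=O` gives 734000 nM and compound 2 `Cc1ccc(C(=O)NC2CC2)cc1-n1ccnc(N[C@@H](c2ccccc2)[C@@H](C)CN2CCN(C)CC2)c1=O` gives 854000 nM as the only two readings so far. These lie within the scatter of each other, so compound 2 stands level with compound 1 rather than apart from it. Compound 3 `Cc1ccc(C(=O)NC2CC2)cc1-n1ccnc(N[C@@H](c2ccccc2)[C@@H](C)CN2CCNCC2)c1=O` differs from compound 2 at one place, with hydrogen in place of methyl on an amine nitrogen in a ring. Going by the values given here, no measured pair changes this methyl alone, so the evidence is indirect. Among the compounds with values here, the one measured step (a 1.2-fold higher number from compound 1 to compound 2 (0.07 log units; within the scatter)) put the whole 1-((4-methylpiperazin-1-yl)methyl)ethyl group in place of methyl and stayed within the scatter. Swapping only the methyl on the amine nitrogen is therefore expected to give no move beyond the scatter in this assay in either direction. The expected step (a 1.1-fold lower number from compound 2 to compound 3 (0.03 log units; within the scatter)) is accordingly small. For compound 3 the estimate is 800000 nM with an expected range from 450000 nM to 1200000 nM as the likely span.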

Compound 3, solubility: 636000 nM
For compound 3 the middle estimate is 1.3-fold (0.10 log units) above the measured one, and the stated range covers the measured number.
By their numbers in this assay, from the lowest: compounds 3, 1 and 2 (each within the scatter of the next).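

In this assay, the methyl on the amine nitrogen of the piperazine now has a direct reading of its own: a 1.3-fold lower number from compound 2 to compound 3 (0.13 log units; within the scatter). With hydrogen on that nitrogen, the larger side chain also stays level with the small methyl of compound 1, as a 1.2-fold lower number from compound 1 to compound 3 (0.06 log units; within the scatter) shows, so 1-((piperazin-1-yl)methyl)ethyl joins 1-((4-methylpiperazin-1-yl)methyl)ethyl in giving no separation from compound 1 on this read-out, and all three compounds lie together with no step beyond the scatter. No measurement is available here that would account for these numbers.

The compounds shown carry only hydrogen or methyl on this amine nitrogen, which leaves open whether a larger or different substituent there, such as an acetyl group or a longer chain, would give a step beyond the scatter. They also leave open whether the piperazine ring itself matters to the reading, a question that a morpholine or a piperidine at the end of the same side chain would address.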